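This account rests on a few compounds, and the source may have more. Where it says the series, first, only, none or still open, it means among the compounds named here.

Working notes on the series in a functional assay on NCI-H661 cells (Homo sapiens) for cytotoxicity, read by WST assay, with a stated time of 72 h; on this read-out lower numbers stand for stronger inhibition and higher numbers for weaker inhibition. Compound 2 `COc1cc2c(Nc3nc4ccc(C(=O)Nc5c(C)cccc5Cl)cc4s3)ncnc2cc1OCCCN1CCCCC1` gives 13800 nM. Going by the values given here, compound 1 `COc1cc2c(Nc3nc4ccc(C(=O)Nc5c(C)cccc5Cl)cc4s3)ncnc2cc1OCCCN1CCCC1` gives 45500 nM in this assay; the only change between the two is pyrrolidin-1-yl in place of piperidin-1-yl on a saturated chain carbon, three bonds along the chain from an oxygen on an aromatic ring, and it produced a 3.3-fold higher number from compound 2 to compound 1 (0.52 log units; beyond the scatter). Compound 3 `COc1cc2c(Nc3nc4ccc(C(=O)Nc5c(C)cc(C)cc5C)cc4s3)ncnc2cc1OCCCN1CCCCC1` gives 10000 nM in this assay; it differs from compound 2 by 2,4,6-trimethylphenyl in place of 2-chloro-6-methylphenyl on an amide-type nitrogen, a change that produced a 1.4-fold lower number from compound 2 to compound 3 (0.14 log units; within the scatter), so the two values are not separable here. Compound 3 has the lowest of the three numbers, but only its gap to compound 1 lies beyond the scatter.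

Compound 4 `COc1cc2c(Nc3nc4ccc(C(=O)Nc5c(C)cc(C)cc5C)cc4s3)ncnc2cc1OCCCN1CCCC1` has not yet been measured in this assay. It differs from compound 3 by pyrrolidin-1-yl in place of piperidin-1-yl on a saturated chain carbon, three bonds along the chain from an oxygen on an aromatic ring, which is the same change that separates compound 1 from compound 2, made on the core of compound 3 instead; the two cores differ only by the change from compound 2 to compound 3 described above. The step from compound 3 to compound 4 is estimated at a 3.0-fold higher number from compound 3 to compound 4 (0.48 log units; beyond the scatter) because the same change gave a 3.3-fold higher number from compound 2 to compound 1 (0.52 log units; beyond the scatter). A single precedent is thin, so the range is kept wide. Compound 4 is therefore expected to give about 30000 nM in this assay, estimated between 12000 nM and 75000 nM.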

Compound 4, half-maximal inhibitory concentration: 9600 nM
Compound 4: middle estimate off by 3.1-fold (0.49 log units), on the high side; measured number outside the range, below it.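

In this assay, pyrrolidin-1-yl in place of piperidin-1-yl gives a 1.0-fold lower number from compound 3 to compound 4 (0.02 log units; within the scatter), so the two values are not separable on the core of compound 3, and the step seen on the core of compound 2 does not carry over: the same change on two cores in this assay, a 3.3-fold higher number (0.52 log units; beyond the scatter) from compound 2 to compound 1 and a 1.0-fold lower number (0.02 log units; within the scatter) from compound 3 to compound 4, 3.4-fold (0.54 log units) apart, beyond the scatter of two such steps. Read along the other edge, 2,4,6-trimethylphenyl in place of 2-chloro-6-methylphenyl gives a 4.7-fold lower number from compound 1 to compound 4 (0.68 log units; beyond the scatter), and this change also depends on its partner group: the same change on two cores in this assay, a 1.4-fold lower number (0.14 log units; within the scatter) from compound 2 to compound 3 and a 4.7-fold lower number (0.68 log units; beyond the scatter) from compound 1 to compound 4, 3.4-fold (0.54 log units) apart, beyond the scatter of two such steps. Both gaps rest on steps that involve compound 1, so one value carries the whole difference, and the four compounds show that the two changes do not add up on these cores, but not why, nor what would happen on a third core.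

Still open, as far as these compounds go, is whether the step seen with 2-chloro-6-methylphenyl would appear with other amide groups, such as 2,6-dimethylphenyl or 2,6-dichlorophenyl. From the compounds shown here alone, the behaviour of a morpholin-4-yl group or of a longer chain in place of the 3-(piperidin-1-yl)propyl group also remains open.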